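Amide-nitrogen substituent change on the shared lipidated core

The compounds below may be only part of what the source reports. "The series", "measured", "known", "first", "only" and "open" are said of these compounds alone.

Compound 1 `CCCCCCCCCCCC(=O)OC[C@H](CSC[C@@H](N)C(=O)N[C@@H](C)CO)OC(=O)CCCCCCCCCCC` is the reference point of the series. Going by the values given here, in an assay on HEK293 cells for agonist activity at Toll-like receptor 2 (Homo sapiens) (on this read-out lower numbers stand for an effect already at smaller amounts and higher numbers for an effect only at larger amounts of compound), compound 1 gives 1560 nM, the lower of the two numbers measured so far. Compound 2 `CCCCCCCCCCCC(=O)OC[C@H](CSC[C@@H](N)C(=O)NCCCS(=O)(=O)O)OC(=O)CCCCCCCCCCC` differs from it only on the amide-type nitrogen; in this assay compound 2 gives 5560 nM, and the step is a 3.6-fold higher number from compound 1 to compound 2 (0.55 log units; beyond the scatter), a modest loss.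

Compound 3 `CCCCCCCCCCCC(=O)OC[C@H](CSC[C@@H](N)C(=O)NCCCCN)OC(=O)CCCCCCCCCCC` has not yet been measured. Its difference from compound 1 is 4-aminobutyl in place of 1-(hydroxymethyl)ethyl on an amide-type nitrogen. Among the compounds with values here, the only measured step at this position is that from compound 1 to compound 2, which introduced 3-sulfopropyl rather than 4-aminobutyl, so it shows only that a change at the amide-type nitrogen costs modestly; no step with 4-aminobutyl exists. For compound 3 a step close to the scatter is expected, a 1.0-fold lower number from compound 1 to compound 3 (0.02 log units; within the scatter). Compound 3 is therefore estimated at 1500 nM, with a range from 500 nM to 5000 nM.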

Compound 3, half-maximal effective concentration: 1040 nM
For compound 3 the middle estimate is 1.4-fold (0.16 log units) above the measured one, within the range that was stated.
By their numbers in this assay, from the lowest: compounds 3 and 1 (each within the scatter of the next); then compound 2.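

In this assay, placing 4-aminobutyl in place of 1-(hydroxymethyl)ethyl on the amide-type nitrogen gives a 1.5-fold lower number from compound 1 to compound 3 (0.18 log units; within the scatter), so this position accepts at least one change with no difference beyond the scatter, and the modest cost seen with 3-sulfopropyl does not extend to every substituent here. The end of the chain carries the difference between the two newer compounds: aminomethyl in place of sulfo, three bonds along the chain from an amide-type nitrogen, gives a 5.3-fold lower number from compound 2 to compound 3 (0.73 log units; beyond the scatter) and recovers what the sulfopropyl compound had lost.

Open, from the compounds shown here alone, is whether a carboxylic acid at the chain end would read like the sulfo group of compound 2 or like the amine of compound 3. Also open, going by these compounds, is whether a shorter or longer aminoalkyl chain holds the number of compound 3.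

No supporting measurement bears on these differences.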